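Propyl to isopropyl on the carbonyl carbon, second instance

The compounds below may be only part of what the source reports. "The series", "measured", "known", "first", "only" and "open" are said of these compounds alone.

Measured so far, in an assay on HEK293 cells for positive allosteric modulation of metabotropic glutamate receptor 2 (Rattus norvegicus), read by thallium flux, with a stated time of 2.5 min; a lower number here means that less compound is needed, a higher number that more compound is needed for the effect:
compound 1, `CCCC(=O)c1ccc(OCCCCOc2cc(C(=O)O)ccc2OC)c(C)c1O`: compound 1 gives 103 nM
compound 2, `COc1ccc(C(=O)O)cc1OCCCCOc1ccc(C(=O)C(C)C)c(O)c1C`: compound 2 gives 116 nM
compound 3, `CCCC(=O)c1ccc(OCCCCOc2ccc(C(=O)O)cc2C)c(C)c1O`: compound 3 gives 104 nM

Compound 2 is compound 1 with isopropyl in place of propyl on a carbonyl carbon. The step this made is a 1.1-fold higher number from compound 1 to compound 2 (0.05 log units; within the scatter), so the two compounds sit within the scatter of each other in this assay and no direction can be read from them.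

Compound 3 carries a different core from compound 1; the difference between the two cores is not broken down here. The two values, however, lie within the scatter of each other.

Compound 4, `Cc1cc(C(=O)O)ccc1OCCCCOc1ccc(C(=O)C(C)C)c(O)c1C`, is to be measured. It is compound 3 with isopropyl in place of propyl on a carbonyl carbon. This is the same change as from compound 1 to compound 2, at the same place: the carbonyl carbon whose other neighbour is an aromatic carbon.

The expected step in this assay is a 1.1-fold higher number from compound 3 to compound 4 (0.04 log units; within the scatter), resting on the earlier pairing, where the step was a 1.1-fold higher number from compound 1 to compound 2 (0.05 log units; within the scatter). Compound 4 is therefore estimated at 115 nM, with a range from 70 nM to 190 nM.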

Compound 4, half-maximal effective concentration: 234 nM
Beside the measured number, compound 4's estimate is 2.0-fold (0.31 log units) below it, outside the stated range (above it).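

In this assay, going by these compounds alone, isopropyl in place of propyl on the carbonyl carbon gives a 2.3-fold higher number from compound 3 to compound 4 (0.35 log units; beyond the scatter), a modest step, whereas the same change on the core of compound 1 gave no step that could be read. Set side by side, the two steps cannot be told apart: the same change on two cores in this assay, a 1.1-fold higher number (0.05 log units; within the scatter) from compound 1 to compound 2 and a 2.3-fold higher number (0.35 log units; beyond the scatter) from compound 3 to compound 4, 2.0-fold (0.30 log units) apart, within the scatter of two such steps. Within the data shown here, the pairs therefore do not show that the core alters the outcome of this change, but neither do they establish that it carries over unaltered: there are only two pairs, and only the step on the core of compound 3 stands beyond the scatter on its own.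

Still open, going by these compounds, is whether cyclopropyl, tert-butyl or a chain longer than propyl on the same carbonyl carbon would follow either of these two steps. Also open, on these data alone, is whether the change would behave the same way on a further core, for example one carrying a tetrazole in place of the carboxylic acid.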